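Swapping the Lactam for Pyrazole on the Sulfonamide Ring

This account rests on a few compounds, and the source may have more. Where it says the series, first, only, none or still open, it means among the compounds named here.

Measured compounds:
Compound 1 `COc1ccc(F)c(-c2ccc(S(=O)(=O)Nc3cc(N4C[C@@H](C)N[C@@H](C)C4)ccc3OC)cc2)c1` — 0.398 nM
Compound 2 `COc1ccc(N2C[C@@H](C)N[C@@H](C)C2)cc1NS(=O)(=O)c1ccc(N2CCCC2=O)cc1` — 39.8 nM

Both compounds were tested in a functional assay for agonist activity at growth hormone secretagogue receptor type 1 (Homo sapiens), read by FLIPR; on this read-out lower numbers stand for an effect already at smaller amounts and higher numbers for an effect only at larger amounts of compound. Within the data shown here, compound 2 gives the highest number of the two measured values; its nearest neighbour is compound 1, which sits a long way lower, and the single step between them, a 100-fold higher number from compound 1 to compound 2 (2.00 log units; beyond the scatter), is large and well beyond the scatter. That step exchanged a bulky substituted phenyl group for a 2-oxopyrrolidin-1-yl group and cost a great deal of potency.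

Compound 3 `COc1ccc(N2C[C@@H](C)N[C@@H](C)C2)cc1NS(=O)(=O)c1ccc(-n2cccn2)cc1` has not yet been measured. It differs from compound 2 in one place: 1H-pyrazol-1-yl in place of 2-oxopyrrolidin-1-yl on an aromatic carbon. Among the measured compounds shown here, no measured step describes exactly this exchange, so the only guidance is indirect. Because a 100-fold higher number from compound 1 to compound 2 (2.00 log units; beyond the scatter) shows how much was lost when a ring of aromatic character was replaced by the lactam, restoring a small aromatic ring in compound 3 is expected to recover part of that loss, though not all of it. Compound 3 is therefore estimated at 15 nM in this assay, within 4 nM to 60 nM, an expected step of a 2.7-fold lower number from compound 2 to compound 3 (0.42 log units; beyond the scatter).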

Compound 3, half-maximal effective concentration: 15.9 nM
The estimate for compound 3 lay 1.1-fold (0.03 log units) below the measured number; measured number inside the range.
By their numbers in this assay, from the lowest: compound 1; then compound 3; then compound 2.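

At this position, para to a large group on a six-membered aromatic ring of carbon only, this assay separates two five-membered rings: putting 1H-pyrazol-1-yl in place of 2-oxopyrrolidin-1-yl gives a 2.5-fold lower number from compound 2 to compound 3 (0.40 log units; beyond the scatter), a modest change, but one that lies beyond the scatter. The aromatic five-membered ring still remains far from the 2-fluoro-5-methoxyphenyl group, with a 40-fold higher number from compound 1 to compound 3 (1.60 log units; beyond the scatter), so this exchange closes only a small part of the large gap seen earlier between the lactam and the substituted phenyl group. No supporting information bears on the reason for either step.

The compounds shown leave open whether the low number of compound 1 depends on its six-membered aromatic ring itself or on the fluorine and methoxy groups attached to that ring, a question that an unsubstituted phenyl group would help to answer. They also leave open how a pyridyl ring, which has a nitrogen atom within a six-membered aromatic ring, would compare with both the 1H-pyrazol-1-yl group and the 2-fluoro-5-methoxyphenyl group at this position.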